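The source may hold more compounds than are shown below. What is called first, only, known or untested is meant among the compounds shown, and "the series" means these compounds.

Measured compounds:

compound 1 `CNC(=O)CCc1ccc(NC(=O)Nc2ccc(Cl)c(C(F)(F)F)c2)cc1`, 20400 nM
compound 2 `C/C(=C\C(=O)N1CC(C)OC(C)C1)c1ccc(NC(=O)Nc2ccc(Cl)c(C(F)(F)F)c2)cc1`, > 50000 nM
compound 3 `CNC(=O)/C=C(\C)c1ccc(NC(=O)Nc2ccc(Cl)c(C(F)(F)F)c2)cc1`, > 50000 nM

All three were run in a functional assay on MX1 cells (Homo sapiens) for inhibition, read by MTT assay, with a stated time of 120 h; on this read-out higher numbers stand for weaker inhibition and lower numbers for stronger inhibition. For the measured compounds named here, compound 1 is the only one to return a number, at 20400 nM. Compound 3 sits at a limit of this assay, > 50000 nM. Compound 2 likewise sits at a limit, > 50000 nM.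

The two cores differ as follows: 2-(methylcarbamoyl)ethyl in place of 1-methyl-2-(methylcarbamoyl)ethenyl on an aromatic carbon. That change gives an at least 2.4-fold higher number from compound 1 to compound 3 (0.38 log units; beyond the scatter), so compound 1 is the more readable starting point of the pair.

The change on the carbonyl carbon, (2,6-dimethylmorpholin-4-yl in place of methylamino on a carbonyl carbon), gives a step that the two limits leave unreadable from compound 3 to compound 2; the step cannot be sized because of the limit of > 50000 nM in this assay, at which 2 of the 3 values shown sit.

Compound 4 `CC1CN(C(=O)CCc2ccc(NC(=O)Nc3ccc(Cl)c(C(F)(F)F)c3)cc2)CC(C)O1` has not yet been run in this assay. It carries the same kind of change on the core of compound 1: 2,6-dimethylmorpholin-4-yl in place of methylamino on a carbonyl carbon. The place is not identical to that in compound 3, where the other neighbour of the carbonyl carbon is a double-bonded chain carbon; in compound 1 and compound 4 it is a saturated chain carbon.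

No readable step exists for this change among the measured compounds, so the expectation for compound 4 rests on compound 1 alone and is wide. The step from compound 1 to compound 4 is estimated at a 1.5-fold higher number from compound 1 to compound 4 (0.17 log units; within the scatter). Compound 4 is expected to give about 30000 nM, between 8000 nM and 100000 nM.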

Compound 4, half-maximal inhibitory concentration: > 50000 nM
Compound 4 ended at the assay's limit; the forecaster's own chance of this, stated with the estimate: 35%; middle value at least 1.6-fold (0.22 log units) from the limit.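

In this assay, on the core of compound 1, 2,6-dimethylmorpholin-4-yl in place of methylamino on a carbonyl carbon gives an at least 2.4-fold higher number from compound 1 to compound 4 (0.38 log units; beyond the scatter), so on this core the change moves the read-out towards weaker inhibition, beyond the scatter. Compound 4 stands at > 50000 nM, which is a limit of the assay and not a number, so the step has a lower bound but no measured size. Whether the change acts alike on the core of compound 1 and the core of compound 3 cannot be said, because the step from compound 3 to compound 2 cannot be read and the true size of the new step stays unknown: the limit of > 50000 nM in this assay, at which 3 of the 4 values shown sit.

Left open is whether a smaller group on the same carbonyl carbon, such as dimethylamino or an unsubstituted morpholin-4-yl, would keep a readable number on the core of compound 1. For the compounds shown here, also open is whether a carboxylic acid in place of the methylcarbamoyl group, or a longer chain carrying it, would move the read-out in either direction from compound 1, the only compound here with a number, at 20400 nM.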